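Triazole carboxamides: aryl swap on the ring nitrogen

This account rests on a few compounds, and the source may have more. Where it says the series, first, only, none or still open, it means among the compounds named here.

Compound 2 `Cc1ccc(-n2nnc(C(=O)Nc3ccc(SC#N)cc3)c2C)cc1C` is measured only as a limit in a functional assay on HaCaT cells (Homo sapiens) for antiproliferative activity, read by MTT assay, with a stated time of 72 h; on this read-out higher numbers stand for weaker inhibition of growth and lower numbers for stronger inhibition of growth: compound 2 gives > 100000 nM, a limit of the assay. Compound 1 `Cc1c(C(=O)Nc2ccc(SC#N)cc2)nnn1-c1ccc(C(C)C)cc1` likewise gives > 100000 nM, again a limit. Among the compounds with values here, the one measured step, a step that the two limits leave unreadable from compound 1 to compound 2, therefore cannot be read, and both values sit at the limit of > 100000 nM in this assay, at which 2 of the 2 values shown sit. Compound 3 `COc1cccc(-n2nnc(C(=O)Nc3ccc(SC#N)cc3)c2C)c1` carries the change (3-methoxyphenyl in place of 3,4-dimethylphenyl on an aromatic nitrogen). No readable step bears on this change, so no shift beyond the scatter is expected and compound 3 is expected to stay at the limit as well, which means a step that the limit leaves unreadable from compound 2 to compound 3. Compound 3 is estimated at 150000 nM, within 50000 nM to 500000 nM.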

Compound 3, concentration for 50% growth inhibition: > 100000 nM
Compound 3: only a limit was reported; the forecaster's own chance of this, stated with the estimate: 85%; the middle value is on the limit's open side.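

In this assay compound 3 gives > 100000 nM, a limit, so its steps from compound 1 and compound 2 cannot be read: the limit of > 100000 nM in this assay, at which 3 of the 3 values shown sit. The compounds shown leave open whether any aryl group on the ring nitrogen of the shared core gives a readable value.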